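The compounds below may be only part of what the source reports. "The series", "measured", "known", "first", "only" and "open" are said of these compounds alone.

In a functional assay on HCT-116 cells (Homo sapiens) for inhibition, read by MTT assay, with a stated time of 48 h (on this read-out lower numbers stand for stronger inhibition and higher numbers for weaker inhibition), compound 1 `CCC/C=C/C(=O)N(Cc1ccc(OC)c(O)c1)c1cc(OC)c(OC)c(OC)c1` gives 95 nM, compound 2 `COc1ccc(CN(C(=O)CN=[N+]=[N-])c2cc(OC)c(OC)c(OC)c2)cc1O` gives 410 nM and compound 3 `COc1ccc(CN(C(=O)CCCCCl)c2cc(OC)c(OC)c(OC)c2)cc1O` gives 220 nM. Compound 3 thus stands within the scatter of compound 2, with a 1.9-fold lower number from compound 2 to compound 3 (0.27 log units; within the scatter), and on the higher side of compound 1, with a 2.3-fold higher number from compound 1 to compound 3 (0.36 log units; beyond the scatter). The next entry, compound 4 `COc1ccc(CN(C(=O)CBr)c2cc(OC)c(OC)c(OC)c2)cc1O`, follows from compound 3 by bromo in place of 3-chloropropyl on a saturated chain carbon bound to a carbonyl carbon. The other measured step at this carbonyl carbon is a 4.3-fold higher number from compound 1 to compound 2 (0.64 log units; beyond the scatter), also modest. Among the measured compounds shown here, no bromo compound has been measured yet, so the closest guide is the small gap between compound 2 and compound 3, and no step beyond the scatter is expected in this assay. The expected step is a 1.5-fold lower number from compound 3 to compound 4 (0.17 log units; within the scatter). Compound 4 is estimated at 150 nM, with an expected range of 40 nM to 450 nM.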

Compound 4, half-maximal inhibitory concentration: 68 nM
Beside the measured number, compound 4's estimate is 2.2-fold (0.34 log units) above it; measured number inside the range.
By their numbers in this assay, from the lowest: compounds 4 and 1 (each within the scatter of the next); then compounds 3 and 2 (each within the scatter of the next).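

In this assay, this carbonyl position now separates the saturated substituents, with a 3.2-fold lower number from compound 3 to compound 4 (0.51 log units; beyond the scatter) and a 6.0-fold lower number from compound 2 to compound 4 (0.78 log units; beyond the scatter) as the new steps, whereas compound 2 and compound 3 stood within the scatter of each other. Bromomethyl and pent-1-en-1-yl stand level (a 1.4-fold lower number from compound 1 to compound 4 (0.15 log units; within the scatter)), so a long chain is not required here. No data bearing on the cause of these steps are at hand.

Open, on these data alone, is whether chloromethyl, iodomethyl or a longer bromoalkyl chain would match bromomethyl. Also open, as far as these compounds go, is how an aminomethyl group would behave at this carbonyl carbon.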